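One chloro on compound 1

The source may hold more compounds than are shown below. What is called first, only, known or untested is meant among the compounds shown, and "the series" means these compounds.

In an ADME assay on S9 fraction from liver (Mus musculus, strain ICR/CD-1) for metabolic stability, read by LC-MS, using NADPH, with a stated time of 5 min, tested at 2 uM (a higher number here means that the compound lasts longer, a lower number that the compound disappears faster), a short half-life marks a compound that disappears quickly. Compound 1 `CC1CCN(C2CCN(S(=O)(=O)c3cccc4ccccc34)CC2)CC1` gives < 0.0834 h, which is a limit of the assay and not a number. Compound 1 therefore stands at the limit of < 0.0834 h in this assay, at which 1 of the 3 values shown sits. Two relatives give numbers. Compound 3 `CC1CCN(C2CCN(S(=O)(=O)c3cc(Br)cc4c3OCC4)CC2)CC1` gives 0.0833 h. Compound 2 `Cc1c(C)c(S(=O)(=O)N2CCC(N3CCC(C)CC3)CC2)c(C)c2c1OC(C)(C)C2` lasts longer, with 1.12 h.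

Compound 4 `CC1CCN(C2CCN(S(=O)(=O)c3ccc(Cl)c4ccccc34)CC2)CC1` keeps the core of compound 1 and makes one change: chloro in place of hydrogen on an aromatic carbon. The new group sits on a six-membered aromatic ring of carbon only, para to a large group. Among the compounds with values here, no pair of measured compounds shows what this swap does, so any forecast for this assay is uncertain. The estimated step, an at least 1.1-fold higher number from compound 1 to compound 4 (0.07 log units; that floor lies within the scatter), is expected to be small and upward, and it may not rise beyond the usual scatter. Compound 4 is estimated to give 0.1 h, with an expected range of 0.05 h to 0.35 h.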

Compound 4, half-life: 0.233 h
The estimate for compound 4 lay 2.3-fold (0.37 log units) below the measured number; the range from low to high includes it.
By their numbers in this assay, from the lowest: compound 3; then compound 4; then compound 2.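

In this assay, chloro in place of hydrogen, para to a large group, gives an at least 2.7-fold higher number from compound 1 to compound 4 (0.44 log units; beyond the scatter). Within the data shown here, this is the first single change that can be read, and it shows that this one carbon of the core of compound 1 can affect how long the compound lasts. The true step may be larger, and its exact size stays unknown because compound 1 gives only a limit of the assay and not a number: the limit of < 0.0834 h in this assay, at which 1 of the 4 values shown sits.

From the compounds shown here alone, whether the rise belongs to chloro itself remains open, as a single group at one carbon cannot show whether a fluoro or a methoxy there would do the same. Going by these compounds, it also remains open whether chloro on another carbon of the same ring would give a similar step.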